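A few compounds are considered here, and "the series" means these few. Any claim that something is new, unique, unknown or untested is made for them only; others in the source may bear on it.

Compound 2 `COc1ccc(Nc2nc3ccccc3nc2S(=O)(=O)c2ccc(OC)cc2)cc1` gives 29100 nM in a functional assay on HCT-116 cells (Homo sapiens) for cytotoxicity, read by MTT assay, with a stated time of 72 h (on this read-out higher numbers stand for weaker inhibition and lower numbers for stronger inhibition), the higher of the two numbers recorded there. Compound 3 `COc1ccc(S(=O)(=O)c2nc3ccccc3nc2Nc2ccc(N)cc2)cc1` gives 6300 nM in this assay, and the step of a 4.6-fold lower number from compound 2 to compound 3 (0.66 log units; beyond the scatter) is the only one that lies beyond the scatter. Compound 1 `COc1ccc(Nc2nc3ccccc3nc2S(=O)(=O)c2ccc(C)cc2)cc1` reaches only a limit of this assay, > 50000 nM. The step of an at least 1.7-fold lower number from compound 1 to compound 2 (0.23 log units; that floor lies within the scatter) is small, its floor lying within the scatter. Compound 4 `COc1ccc(Nc2nc3ccccc3nc2S(=O)(=O)c2ccc(F)cc2)cc1` differs from compound 2 by fluoro in place of methoxy on an aromatic carbon. Neither measured step repeats this change: the step from compound 1 to compound 2 swaps groups on the same ring and is small, while the step from compound 2 to compound 3 changes the other ring. The expectation is therefore no step beyond the scatter, or a slight move toward weaker inhibition, from compound 2 to compound 4, a 1.4-fold higher number from compound 2 to compound 4 (0.14 log units; within the scatter). Compound 4 is estimated at 40000 nM, within a range from 15000 nM to 100000 nM. It may also end at the limit of this assay, (the limit of > 50000 nM in this assay, at which 1 of the 3 values shown sits).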

Compound 4, half-maximal inhibitory concentration: 3010 nM
Estimate against measurement, compound 4: 13-fold (1.12 log units) above, outside the stated range (below it).
By their numbers in this assay, from the lowest: compound 4; then compound 3; then compound 2. At a limit, above all of these: compound 1.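

In this assay, the position that had so far shown only a small step, with its floor within the scatter, now shows a step well beyond it: the change from 4-methoxyphenyl to 4-fluorophenyl gives a 9.7-fold lower number from compound 2 to compound 4 (0.99 log units; beyond the scatter). Fluoro in place of methyl at this same position gives an at least 16-fold lower number from compound 1 to compound 4 (1.22 log units; beyond the scatter), so the group held here can move the number substantially without any change to the other ring. Compound 1 stands at a limit of the assay rather than at a number, so that second step is only a floor: the limit of > 50000 nM in this assay, at which 1 of the 4 values shown sits.

Why fluoro stands apart from methoxy and methyl cannot be told from these compounds. As far as these compounds go, whether chloro or a nitrile at this position would behave like fluoro remains open, as does whether fluoro here would combine with the amino group of compound 3 on the other ring.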